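The source may report more compounds than this note shows. Statements on the series, on what has been measured and on what is new or still open speak of the compounds shown alone.

Measured in a functional assay on U-251 cells (Homo sapiens) for cytotoxicity, read by sulforhodamine B assay, with a stated time of 48 h; on this read-out lower numbers stand for stronger inhibition of growth and higher numbers for weaker inhibition of growth:
- compound 1 `ClCc1ccc(Cn2cnc3c(Cl)ncnc32)cc1` gives 1250 nM
- compound 2 `ClCc1ccccc1Cn1cnc2c(Cl)nc(Cl)nc21` gives 310 nM

Of these two, compound 2 stands at the lower number, while the number for compound 1 is higher by a gap beyond the usual scatter. Compound 3 `ClCc1ccccc1Cn1cnc2c(Cl)ncnc21` has not yet been measured. Its difference from compound 2 is hydrogen in place of chloro on an aromatic carbon. No directly comparable step has been measured, so the expectation rests on the two numbers shown. The step in this assay is expected to run toward weaker inhibition of growth, by a modest amount that may just exceed the scatter. Compound 3 is estimated at 750 nM, with a range from 250 nM to 2200 nM. This estimate corresponds to an expected step of a 2.4-fold higher number from compound 2 to compound 3 (0.38 log units; beyond the scatter).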

Compound 3, concentration for 50% growth inhibition: 2630 nM
For compound 3 the middle estimate is 3.5-fold (0.54 log units) below the measured one; measured number above the stated range.
By their numbers in this assay, from the lowest: compound 2; then compound 1; then compound 3.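

In this assay replacing the chloro group between two ring nitrogen atoms with hydrogen gives an 8.5-fold higher number from compound 2 to compound 3 (0.93 log units; beyond the scatter) and so weakens inhibition of growth beyond the scatter. Within the data shown here, this is the first change in one place alone, and it shows that in this pair the chloro group at this position matters for growth inhibition. Nothing measured here explains the loss. Going by these compounds, whether an amine or a methoxy group at this position would keep the inhibition of compound 2 remains open.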